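The compounds below may be only part of what the source reports. "The series", "measured", "known", "first", "only" and "open" are said of these compounds alone.

Compound 2 `COc1ccc(-c2cc(-c3ccc(-n4cccn4)cc3)cnc2N)cn1` and compound 1 `COc1ccc(-c2cc(-c3ccc(-n4cncn4)cc3)cnc2N)cn1` share one core and differ in a single ring. In an in vitro ADME assay on microsomes from liver (Homo sapiens) for metabolic stability (on this read-out higher numbers stand for a longer-lived compound and lower numbers for a shorter-lived compound), compound 2 gives 3.38 h, and compound 1 gives 3.5 h; the two sit within the scatter of each other, as a 1.0-fold lower number from compound 1 to compound 2 (0.02 log units; within the scatter) shows. Compound 3 `COc1ccc(-c2cc(-c3ccc(C(N)=O)cc3)cnc2N)cn1` differs from compound 2 by carbamoyl in place of 1H-pyrazol-1-yl on an aromatic carbon. For the measured compounds named here, the only measured step swaps one five-membered ring for another and stayed within the scatter, so it bears on this change only loosely. Compound 3 is therefore estimated at 3.4 h, with a range from 1.5 h to 7.5 h. The expected step is a 1.0-fold higher number from compound 2 to compound 3 (0.00 log units; within the scatter), no change beyond the scatter.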

Compound 3, half-life: > 4.16 h
Compound 3: no number, only a limit; the forecaster's own chance of this, stated with the estimate: 5%; at least 1.2-fold (0.08 log units) between middle value and limit.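

In this assay compound 3 carries a limit of the assay and not a number: the limit of > 4.16 h in this assay, at which 1 of the 3 values shown sits. The comparisons therefore give only floors: an at least 1.2-fold higher number from compound 2 to compound 3 (0.09 log units; that floor lies within the scatter), and an at least 1.1-fold higher number from compound 1 to compound 3 (0.07 log units; that floor lies within the scatter). Even so, on this aromatic carbon, para to a large group, carbamoyl with no ring can stand in place of either five-membered aromatic ring with no sign of a shorter half-life.

As far as these compounds go, the true size of both steps stays open. So does the outcome with a carboxylic acid or an amine at this place.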